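Fluoro removal on the shared core, cytotoxicity series

The source may report more compounds than this note shows. Statements on the series, on what has been measured and on what is new or still open speak of the compounds shown alone.

Measured compounds:
compound 1 `O=c1nc(NO)c(F)cn1[C@@H]1C[C@@H](O)[C@H](CO)O1` — 920000 nM
compound 2 `Cc1cn([C@@H]2CC[C@H](CO)O2)c(=O)nc1N` — 1550000 nM
compound 3 `Cc1cn([C@@H]2C=C[C@H](CO)O2)c(=O)nc1N` — 1400000 nM

In an ADME assay on HepG2 cells (Homo sapiens) for cytotoxicity, read by MTT assay, with a stated time of 3 days (on this read-out higher numbers stand for lower toxicity in this test and lower numbers for higher toxicity in this test), compound 1 gives 920000 nM, compound 2 gives 1550000 nM and compound 3 gives 1400000 nM. Compound 1 carries the nominally smallest number of the three, yet its gaps to compound 3 and to compound 2 both fall within the scatter, so nothing separates the three on this read-out. Among the compounds with values here, no step between measured compounds is available.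

Compound 4 `O=c1nc(NO)ccn1[C@@H]1C[C@@H](O)[C@H](CO)O1` is not yet measured in this assay. It differs from compound 1 by hydrogen in place of fluoro on an aromatic carbon. Within the data shown here, with no measured step to lean on, the expected step of a 1.1-fold higher number from compound 1 to compound 4 (0.04 log units; within the scatter) is none beyond the scatter. Compound 4 is thus estimated at 1000000 nM, range 400000 nM to 2500000 nM.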

Compound 4, half-maximal cytotoxic concentration: 545000 nM
Compound 4: the middle estimate sits 1.8-fold (0.26 log units) above what was measured, and the stated range covers the measured number.
By their numbers in this assay, from the lowest: compounds 4, 1, 3 and 2 (each within the scatter of the next, the first and the last beyond it).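

Hydrogen in place of fluoro on the aromatic carbon ortho to the hydroxyamino group gives a 1.7-fold lower number from compound 1 to compound 4 (0.23 log units; within the scatter) in this assay. Within the data shown here, this is the only one-place comparison, and on this read-out the fluoro shows no effect beyond the scatter on the shared core. No measured evidence bears on the reason for this result.

A single swap cannot show how tolerant this position is overall. Larger or differently built groups on the same aromatic carbon, such as chloro, a nitrile or a carboxylic acid, remain open.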